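This account rests on a few compounds, and the source may have more. Where it says the series, first, only, none or still open, it means among the compounds named here.

Compound 2 `COCC(COC)N(C)c1nc(C)nc2c1nnn2-c1ccc(C(C)C)cc1Br` is followed here into compound 3 `CCCCC(CC)Nc1nc(C)nc2c1nnn2-c1ccc(C(C)C)cc1Br`. For the measured compounds named here, in an in vitro assay on 293-EBNA cells for binding affinity to corticotropin-releasing factor receptor 1 (Homo sapiens) (on this read-out lower numbers stand for stronger inhibition and higher numbers for weaker inhibition), compound 2 gives 21.3 nM, the lower of the two numbers known so far, while compound 1 `CCCCN(CC)c1nc(C)nc2c1nnn2-c1c(C)cc(C)cc1C` gives 27.5 nM, and the two lie within the scatter of each other, so neither can be called stronger. The change from compound 2 to compound 3 is a group of 8 heavy atoms (7 carbon, 1 nitrogen; no ring) in place of a group of 9 heavy atoms (6 carbon, 1 nitrogen, 2 oxygen; no ring), on an aromatic carbon. Going by the values given here, no step of this kind has been measured, so a small step in this assay, downward or none beyond the scatter, is expected. Compound 3 is estimated at 15 nM, between 4 nM and 60 nM, an expected step of a 1.4-fold lower number from compound 2 to compound 3 (0.15 log units; within the scatter).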

Compound 3, inhibition constant: 3.1 nM
Compound 3: middle estimate off by 4.8-fold (0.68 log units), on the high side, outside the stated range (below it).
By their numbers in this assay, from the lowest: compound 3; then compounds 2 and 1 (each within the scatter of the next).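

In this assay, putting (1-ethylpentyl)amino in place of the group of 9 heavy atoms on this aromatic carbon gives a 6.9-fold lower number from compound 2 to compound 3 (0.84 log units; beyond the scatter). This shows that the number responds to the group at this position, which compounds 1 and 2, differing in more than one place, could not show. No measurement given here accounts for the step. The compounds shown leave open whether the hydrogen-bond donor or the chain carries the step. A methyl group on the nitrogen of (1-ethylpentyl)amino, or a shorter chain such as (1-ethylpropyl)amino, would separate the two.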